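The compounds below may be only part of what the source reports. "The series", "measured", "known", "first", "only" and "open" are said of these compounds alone.

Among the compounds with values here, in an ADME assay on MCF7-DOX cells (Homo sapiens) for cytotoxicity, read by MTT assay, with a stated time of 48 h (a lower number here means a stronger inhibitor, a higher number a weaker inhibitor), only two compounds have been measured so far. Within the data shown here, compound 1 `COc1cc(OC)c(C(=O)/C=C/c2ccc(C(F)(F)F)cc2)c(O)c1CC=C(C)C` gives 73700 nM, the only actual number available. Compound 2 `CCCc1c(OC)cc(OC)c(C(=O)/C=C/c2cccc(N3CCNCC3)c2)c1O` gives > 100000 nM, which is a limit of the assay and not a number.

Compound 3 `COc1cc(OC)c(C(=O)/C=C/c2ccc(Cl)cc2)c(O)c1CC=C(C)C` keeps the core of compound 1 and changes it in one place. It carries chloro in place of trifluoromethyl on an aromatic carbon, para to a large group: chloro in place of trifluoromethyl on an aromatic carbon. Among the measured compounds shown here, the two measured compounds differ in more than one place, so no measured step shows what such an exchange does in this assay.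

The expectation therefore rests on compound 1 alone, at 73700 nM, as the anchor for compound 3. No shift beyond the usual scatter is foreseen, although a small move toward stronger inhibition would not be surprising. The expected change, a 1.2-fold lower number from compound 1 to compound 3 (0.09 log units; within the scatter), is estimated to remain within that scatter. For compound 3, the estimated value is 60000 nM, with an expected range from 25000 nM to 100000 nM.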

Compound 3, half-maximal inhibitory concentration: 43400 nM
Compound 3: middle estimate off by 1.4-fold (0.14 log units), on the high side, and the stated range covers the measured number.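

With this result, the exchange of trifluoromethyl for chloro on an aromatic carbon, para to a large group, has a measured step in this assay: a 1.7-fold lower number from compound 1 to compound 3 (0.23 log units; within the scatter). The earlier compounds shown here offered no such reading, and it now shows that, on the core of compound 1, the four heavy atoms of trifluoromethyl can give way to the single atom of chloro without a difference that stands clear of the scatter. Compound 2 is given only as a limit of the assay, not a number, and it differs from compound 3 in more than one place, so it adds no step to this comparison: the limit of > 100000 nM in this assay, at which 1 of the 3 values shown sits.

The compounds shown leave open what a different group at this position, such as a nitrile or a carboxylic acid, would do on the shared core, as only trifluoromethyl and chloro have been seen there. They also leave open whether this exchange would give a similar step on another core, and what a single change elsewhere on the core of compound 1 would do in this assay.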